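The source may report more compounds than this note shows. Statements on the series, on what has been measured and on what is new or still open speak of the compounds shown alone.

In a functional assay on A549 cells (Homo sapiens) for inhibition, read by MTT assay, with a stated time of 72 h (a lower number here means a stronger inhibitor, a higher number a weaker inhibitor), compound 1 (`CCCc1ccc(NC(=O)C2CCN(C/C=C/c3ccccc3)CC2)cc1`) gives 9470 nM. Compound 2 (`CCCCc1ccc(NC(=O)C2CCN(C/C=C/c3ccccc3)CC2)cc1`) gives 5910 nM, so the two stand within the scatter of each other, and no other measured number places compound 1 any further. Compound 3 (`O=C(Nc1cccc(Cl)c1)C1CCN(C/C=C/c2ccccc2)CC1`) has not yet been measured. It carries 3-chlorophenyl in place of 4-propylphenyl on an amide-type nitrogen. Among the measured compounds shown here, one measured step bears on this change, and only indirectly: a 1.6-fold lower number from compound 1 to compound 2 (0.20 log units; within the scatter), with a methyl in place of hydrogen on a saturated chain carbon. That step stays within the scatter. For the measured compounds named here, no measured compound tests the chlorine, so the data give no firm direction, and no step beyond the scatter is expected. The expected step is a 1.2-fold higher number from compound 1 to compound 3 (0.07 log units; within the scatter). For compound 3 the estimated value is 11000 nM, with an expected range from 4500 nM to 27000 nM.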

Compound 3, half-maximal inhibitory concentration: 19100 nM
Compound 3: the middle estimate sits 1.7-fold (0.24 log units) below what was measured; the measured number falls inside the stated range.
By their numbers in this assay, from the lowest: compounds 2, 1 and 3 (each within the scatter of the next, the first and the last beyond it).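

Exchanging the whole aryl group on the amide-type nitrogen, 3-chlorophenyl in place of 4-propylphenyl, gives a 2.0-fold higher number from compound 1 to compound 3 (0.30 log units; within the scatter) in this assay. Where the earlier pair varied only the length of a saturated chain, this step shows that the propyl chain can be given up and a chlorine taken on at this position with the two compounds still standing within the scatter of each other. Nothing measured accounts for this result.

The change removes the chain and brings in the chlorine in a single step, so the share of each stays unresolved. From the compounds shown here alone, whether a plain phenyl, a methoxy group or an amine on this ring would stay within the same scatter also remains open.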